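A Fluoro for Methoxy Swap in a Cytotoxicity Series

This account rests on a few compounds, and the source may have more. Where it says the series, first, only, none or still open, it means among the compounds named here.

Three compounds built on one shared core all meet the same ceiling in a functional assay on MDA-MB-231 cells (Homo sapiens) for cytotoxicity, read by MTT assay, with a stated time of 48 h; on this read-out higher numbers stand for weaker inhibition and lower numbers for stronger inhibition. Compound 1 `Fc1cccc(-c2nc(Nc3ccccc3)c3ccccc3n2)c1` returns only a limit, > 50000 nM. Compound 2 `Fc1ccc2nc(-c3ccccc3)nc(Nc3ccccc3)c2c1` likewise returns only a limit, > 50000 nM. Compound 3 `COc1ccccc1Nc1nc(-c2cccc(F)c2)nc2ccc(F)cc12`, the starting point here, also returns only a limit, > 50000 nM. Compound 3 therefore cannot be ranked against compound 1 or compound 2 by number; all three sit at the limit of > 50000 nM in this assay, at which 3 of the 3 values shown sit. Compound 4 `Fc1cccc(-c2nc(Nc3ccccc3F)c3cc(F)ccc3n2)c1` differs from compound 3 in one place: fluoro in place of methoxy on an aromatic carbon, ortho to a large group. For the measured compounds named here, with no measured step to lean on and three limits pointing nowhere, no change beyond the scatter is expected, and the step that the limit leaves unreadable from compound 3 to compound 4 is estimated as essentially flat in this assay. Compound 4 is estimated at 70000 nM, within 20000 nM to 250000 nM, most likely again reported only as a limit.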

Compound 4, half-maximal inhibitory concentration: > 50000 nM
Compound 4 gave a limit, no number; the forecaster's own chance of this, stated with the estimate: 85%; the middle value lies beyond the limit too.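

Compound 3 and compound 4 each return only a limit, so no step can be read between them: the limit of > 50000 nM in this assay, at which 4 of the 4 values shown sit. In this assay the compounds shown leave open whether fluoro in place of methoxy changes the read-out at all.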